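A few compounds are considered here, and "the series" means these few. Any claim that something is new, unique, unknown or untested is made for them only; others in the source may bear on it.

Measured compounds, each with its value in a functional assay on LNCaP cells (Homo sapiens) for cytotoxicity, read by MTT assay, with a stated time of 48 h, in the presence of a further agent that is not named here; on this read-out lower numbers stand for stronger inhibition and higher numbers for weaker inhibition:
compound 1 `COc1cc(NC(=O)c2csc(-c3c[nH]c4ccc(Br)cc34)n2)cc(OC)c1OC` gives > 100000 nM, a limit of the assay
compound 2 `O=C(Nc1ccccc1)c1csc(-c2cn(Cc3ccc(Cl)cc3)c3ccccc23)n1` gives 68900 nM
compound 3 `O=C(Nc1ccccc1)c1csc(-c2c[nH]c3ccccc23)n1` gives > 100000 nM, a limit of the assay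

Compound 3 thus stands at a limit of this assay and not at a number, and the limit of > 100000 nM in this assay, at which 2 of the 3 values shown sit, shows where two of the three measurements sit. Compound 4 `Cc1ccc(NC(=O)c2csc(-c3c[nH]c4ccccc34)n2)cc1` differs from compound 3 in one place: methyl in place of hydrogen on an aromatic carbon. For the measured compounds named here, only one measured step exists, an at least 1.4-fold higher number from compound 2 to compound 3 (0.16 log units; that floor lies within the scatter), and it concerns a different place, hydrogen in place of 4-chlorobenzyl on an aromatic nitrogen; no measured step touches methyl in place of hydrogen on an aromatic carbon. The step is therefore expected to stay within the scatter, a number no higher from compound 3 to compound 4 (the limit leaves the size open). Compound 4 is estimated at 100000 nM, in a range from 40000 nM to 250000 nM, with another limit the likeliest outcome.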

Compound 4, half-maximal inhibitory concentration: > 100000 nM
Compound 4 gave a limit, no number (the forecaster's own chance of this, stated with the estimate: 65%); the middle value sits exactly at the limit.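

For the compounds shown here, compound 3 and compound 4 both sit at a limit of this assay, so no step between them can be read: the limit of > 100000 nM in this assay, at which 3 of the 4 values shown sit.

The compounds shown leave open whether methyl in place of hydrogen on an aromatic carbon changes the value at all.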